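Heteroaryl exchange on the saturated ring carbon: compound 4

This account rests on a few compounds, and the source may have more. Where it says the series, first, only, none or still open, it means among the compounds named here.

Measured so far in an assay on HeLa cells for displacement of a labelled ligand from adenosine receptor A3 (Homo sapiens), read by radioligand binding, with a stated time of 180 min, tested at 1 uM; a lower number here means less inhibition, a higher number more inhibition at the concentration tested (going by the name of the read-out):
compound 1 `CC(C)OC(=O)C1=C(C(F)(F)F)NC(=O)NC1c1ccsc1`: 3%
compound 2 `CC(C)OC(=O)C1=C(C(F)(F)F)NC(=O)NC1c1ccoc1`: 1%
compound 3 `CC(C)OC(=O)C1=C(C(F)(F)F)NC(=O)NC1c1ccco1`: 5%

All three numbers sit close to the floor of this assay. Compound 3 holds the highest of the three, but its neighbours are within the scatter of it: a number 2 percentage points higher from compound 1 to compound 3 (within the scatter) and a number 4 percentage points higher from compound 2 to compound 3 (within the scatter), so no order among the three is established.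

Compound 4 `CC(C)OC(=O)C1=C(C(F)(F)F)NC(=O)NC1c1cccs1` differs from compound 3 in one place: thiophen-2-yl in place of furan-2-yl on a saturated ring carbon.

For the measured compounds named here, two measured steps bear on this change. The exchange of the ring hetero atom, sulfur for oxygen at the same attachment point, is seen in a number 2 percentage points lower from compound 1 to compound 2 (within the scatter), within the scatter. The shift of the attachment point from the 3-position to the 2-position of the five-membered ring is seen in a number 4 percentage points higher from compound 2 to compound 3 (within the scatter), also within the scatter. Neither component of the change to compound 4 has moved the read-out in this assay beyond the scatter, so no step beyond the scatter is expected here either, in either direction.

For compound 4 the expected result in this assay is therefore 5%, with a range of 0% to 14%, meaning an expected step of no change at the digits printed from compound 3 to compound 4 (within the scatter).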

Compound 4, a percentage reported as inhibition, at one concentration (the size of the read-out at that concentration, not a potency): 7%
Compound 4: middle estimate off by 2 percentage points, on the low side, within the range that was stated.
By their numbers in this assay, from the lowest: compounds 2, 1, 3 and 4 (each within the scatter of the next).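

With thiophen-2-yl on the saturated ring carbon, all four combinations of furan or thiophen with attachment at the 2- or 3-position are in hand, and this assay gives a number 2 percentage points higher from compound 3 to compound 4 (within the scatter) and a number 6 percentage points higher from compound 2 to compound 4 (within the scatter) and also a number 4 percentage points higher from compound 1 to compound 4 (within the scatter) as its new steps. Neither the hetero atom nor the attachment point therefore gives any step beyond the scatter among these four heteroaryl groups, and all four sit close to the floor of the assay. No measurement at hand accounts for this flat result.

Going by these compounds, it remains open whether a different kind of group at this carbon, such as a phenyl ring bearing a carboxylic acid or an amine, would reach a number beyond the scatter. On these data alone, the isopropoxycarbonyl and trifluoromethyl groups are the same throughout, so their part in these low numbers also remains open.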